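Phenethyl on the sulfur: next step in the series

This account rests on a few compounds, and the source may have more. Where it says the series, first, only, none or still open, it means among the compounds named here.

In a functional assay on HeLa cells (Homo sapiens) for inhibition, read by CCK-8 assay, with a stated time of 72 h, tested at 8 uM (on this read-out higher numbers stand for more inhibition of growth at the one concentration tested and lower numbers for less inhibition of growth), compound 3 `Nc1ccccc1NC(=O)/C=C/c1ccc(CSc2ccc(C(F)(F)F)cn2)cc1` gives 6.82% and cannot be told apart from compound 1 `Cc1cc(C)cc(SCc2ccc(/C=C/C(=O)Nc3ccccc3N)cc2)c1` at 3.39% while compound 2 `CCc1ccc(SCc2ccc(/C=C/C(=O)Nc3ccccc3N)cc2)cc1` stands clearly higher at 20.9% in the set of three. Going by the values given here, compound 4 `Nc1ccccc1NC(=O)/C=C/c1ccc(CSCCc2ccccc2)cc1` carries phenethyl in place of 5-(trifluoromethyl)pyridin-2-yl on a sulfur and no measured compound holds this group. Changes at this sulfur have so far given a number 3.4 percentage points higher from compound 1 to compound 3 (within the scatter) as well as a number 17.5 percentage points higher from compound 1 to compound 2 (beyond the scatter) and a number 14.1 percentage points lower from compound 2 to compound 3 (beyond the scatter) so modest steps are the largest seen. The expected result in this assay is a number 5.2 percentage points higher from compound 3 to compound 4 (within the scatter) as a slight rise at most. Compound 4 is estimated at 12% within a range of 3% to 27% for now.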

Compound 4, percent growth inhibition at one concentration: 3.57%
The estimate for compound 4 lay 8.4 percentage points above the measured number; measured number inside the range.
By their numbers in this assay, from the lowest: compounds 1, 4 and 3 (each within the scatter of the next); then compound 2.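

In this assay, going by these compounds alone, phenethyl, the first group here whose ring does not sit directly on the sulfur, brings no readable change, with a number 3.3 percentage points lower from compound 3 to compound 4 (within the scatter) and a number 0.2 percentage points higher from compound 1 to compound 4 (within the scatter). Only 4-ethylphenyl stands apart among the four groups on this sulfur, with a number 17.3 percentage points lower from compound 2 to compound 4 (beyond the scatter). No measurement at hand accounts for this.

Going by these compounds, whether an amine or a carboxylic acid on a chain at this sulfur would match or pass compound 2 stays open. Also open, on these data alone, is how these compounds would compare at other concentrations.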